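The source may report more compounds than this note shows. Statements on the series, on what has been measured and on what is new or still open speak of the compounds shown alone.

This small set of compounds shares one core, and the question is how swapping one amine group at the end of a short side chain affects cell-killing potency. Within the data shown here, compound 2 `CCN(CC)CCCOc1cc(O)c2c(=O)cc(-c3ccccc3)oc2c1OC` is the only member with a number: in a functional assay on A549 cells (Homo sapiens) for cytotoxicity, read by MTT assay, with a stated time of 48 h (on this read-out lower numbers stand for stronger inhibition and higher numbers for weaker inhibition), compound 2 gives 1830 nM. Two relatives were prepared but no result was reported for either: in this assay compound 1 `CC(C)NCCOc1c(O)cc(O)c2c(=O)cc(-c3ccccc3)oc12` gives "not determined" (no result reported), and in this assay compound 3 `O=c1cc(-c2ccccc2)oc2c(OCCNCCO)c(O)cc(O)c12` gives "not determined" (no result reported). So compound 2 stands alone as the reference point, with nothing to rank it against.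

Compound 4 `COc1c(OCCCNCc2ccccc2)cc(O)c2c(=O)cc(-c3ccccc3)oc12` has not been tested. Compared with compound 2, the change is benzylamino in place of diethylamino on a saturated chain carbon, three bonds along the chain from an oxygen on an aromatic ring. The rest of the molecule, including the core and the side chain that carries the amine, is unchanged.

Among the measured compounds shown here, with no measured pair in this set showing what such a swap does, there is no basis for expecting a large shift in either direction. The best guess is a step from compound 2 to compound 4 of roughly a 1.2-fold lower number from compound 2 to compound 4 (0.09 log units; within the scatter) in this assay, that is, a change that stays within the usual scatter of repeated measurements. On that basis, compound 4 is expected to give about 1500 nM, with a plausible range from 500 nM to 5000 nM.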

Compound 4, half-maximal inhibitory concentration: 1570 nM
Estimate against measurement, compound 4: 1.0-fold (0.02 log units) below; measured number inside the range.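

In this assay, among these compounds, the change to benzylamino from diethylamino gives a 1.2-fold lower number from compound 2 to compound 4 (0.07 log units; within the scatter) and is the first step in this set that can be read at all. On a saturated chain carbon, three bonds along the chain from an oxygen on an aromatic ring, the amine can therefore gain a six-membered aromatic ring of carbon and a hydrogen-bond donor, and the two compounds still cannot be told apart on this read-out. This is a single pair, and no measurement shown explains why the two amines read alike.

From the compounds shown here alone, what stays open is whether other groups at the end of this chain, such as a morpholine, a piperidine or a plain primary amine, would also leave the number within the scatter, or whether one of them would move it clearly in either direction. Going by these compounds, a longer chain between the oxygen and the amine is equally open, and so is the question of whether the same swap would behave this way on a chain of another length.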